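The compounds below may be only part of what the source reports. "The series", "measured", "known", "first", "only" and "open" are said of these compounds alone.

Of the compounds shown here, three have so far been tested in a functional assay on HeLa cells (Homo sapiens) for antiproliferative activity, read by MTT assay, with a stated time of 72 h; on this read-out lower numbers stand for stronger inhibition and higher numbers for weaker inhibition. Compound 1 `COc1cccc(N2C(=O)COc3ccc(-c4cnc(OC)c(NS(=O)(=O)c5ccc(F)cc5)c4)cc32)c1` gives only a limit of the assay, > 40000 nM. Compound 2 `COc1cccc(N2C(=O)COc3ccc(-c4cnc5ccccc5c4)cc32)c1` gives 11400 nM and compound 3 `O=C1COc2ccc(-c3cnc(Cl)c(NS(=O)(=O)c4ccc(F)cc4)c3)cc2N1` gives 15600 nM. These two numbers lie within the usual scatter of each other, so compound 2 stands level with compound 3.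

The next compound to be tested is compound 4 `Cc1ccc(N2C(=O)COc3ccc(-c4cnc5ccccc5c4)cc32)cc1`, which keeps the core of compound 2 and differs in one group, with 4-methylphenyl in place of 3-methoxyphenyl on an amide-type nitrogen in a ring. For the measured compounds named here, no pair of measured compounds shows the effect of such a change in this assay, so the expectation rests on compound 2 alone, at 11400 nM, and no shift beyond the scatter is foreseen in either direction. The expected change is a 1.1-fold lower number from compound 2 to compound 4 (0.06 log units; within the scatter). Compound 4 is estimated at 10000 nM, with an expected range from 3500 nM to 30000 nM.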

Compound 4, half-maximal inhibitory concentration: > 40000 nM
Compound 4: no number, only a limit; the forecaster's own chance of this, stated with the estimate: 10%; middle value at least 4.0-fold (0.60 log units) from the limit.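

In this assay, for the compounds shown here, the group on the amide-type nitrogen in a ring proves not to be interchangeable: 4-methylphenyl in place of 3-methoxyphenyl gives an at least 3.5-fold higher number from compound 2 to compound 4 (0.54 log units; beyond the scatter), the first readable step at this position. Compound 4 gives > 40000 nM, which is a limit of the assay and not a number. As far as these compounds go, the step therefore has only a lower bound, and its true size stays unknown because the value of compound 4 sits at that limit: the limit of > 40000 nM in this assay, at which 2 of the 4 values shown sit.

The compounds shown leave open whether the step follows from the change of methoxy to methyl or from the different placement on the phenyl ring, since compound 4 changes both at once. A 3-methylphenyl or 4-methoxyphenyl group at this position would separate the two, and an unsubstituted phenyl group would show how much either substituent matters.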